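The source may hold more compounds than are shown below. What is called first, only, known or untested is meant among the compounds shown, and "the series" means these compounds.

Series notes. In an assay on FRT cells for positive allosteric modulation of Cystic fibrosis transmembrane conductance regulator variant N1303K (Homo sapiens), in the presence of a further agent that is not named here (on this read-out lower numbers stand for an effect already at smaller amounts and higher numbers for an effect only at larger amounts of compound), compound 1 `COc1ccc2[nH]c3c(c2c1)CCNC31CCN(Cc2ccc(Cl)cc2Cl)CC1` gives 1800 nM and compound 2 `COc1ccc2[nH]c3c(c2c1)CCNC31CCN(Cc2ccc(Br)c(F)c2)CC1` gives 1800 nM, so compound 2 stands level with compound 1 on the numbers at hand. Among the measured compounds shown here, the only measured step, no change at the digits printed from compound 1 to compound 2 (within the scatter), exchanged one halogenated phenyl for another without moving the read-out. Compound 3 `COc1ccc2[nH]c3c(c2c1)CCNC31CCN(Cc2ccc(F)cc2F)CC1` carries the next exchange of that kind: 2,4-difluorophenyl in place of 4-bromo-3-fluorophenyl on a saturated chain carbon bound to an amine nitrogen in a ring. For the measured compounds named here, the single step that bears on it lay within the scatter, so in this assay no step beyond the scatter is expected, perhaps a slight drift toward larger amounts, because the one measured exchange gave no change at the digits printed from compound 1 to compound 2 (within the scatter). The expected step is a 1.4-fold higher number from compound 2 to compound 3 (0.14 log units; within the scatter). Compound 3 is therefore estimated at 2500 nM, within 1000 nM to 6000 nM.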

Compound 3, half-maximal effective concentration: 2000 nM
The estimate for compound 3 lay 1.3-fold (0.10 log units) above the measured number, and the stated range covers the measured number.
By their numbers in this assay, from the lowest: compounds 1, 2 and 3 (each within the scatter of the next).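

In this assay, the step to the third halogen pattern at this position, on a saturated chain carbon bound to an amine nitrogen in a ring, stays within the scatter: 2,4-difluorophenyl in place of 4-bromo-3-fluorophenyl gives a 1.1-fold higher number from compound 2 to compound 3 (0.05 log units; within the scatter). 2,4-Difluorophenyl in place of 2,4-dichlorophenyl likewise gives a 1.1-fold higher number from compound 1 to compound 3 (0.05 log units; within the scatter). These halogen exchanges therefore separate none of the three compounds, and nothing at hand explains this. Still open, going by these compounds, is whether a nitrile or a carboxylic acid on the phenyl ring, or a longer chain in place of the benzyl carbon, would move the read-out.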